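This account rests on a few compounds, and the source may have more. Where it says the series, first, only, none or still open, it means among the compounds named here.

Compound 1 `O=c1cc(-c2ccccc2)oc2cc(O)c(OCCCN3CCCCC3)c(O)c12` gives 60900 nM in a functional assay on BCG823 cells (Homo sapiens) for antiproliferative activity, read by MTT assay, with a stated time of 48 h; on this read-out lower numbers stand for stronger inhibition and higher numbers for weaker inhibition.
Compound 2 `O=c1cc(-c2ccccc2)oc2cc(O)c(OCCCCN3CCCCC3)c(O)c12` gives 52700 nM in this assay.
Compound 3 `COc1cc2oc(-c3ccccc3)cc(=O)c2c(O)c1OCCCCN1CCN(C)CC1` gives 53500 nM in this assay.

Within the data shown here, all three numbers sit close together; compound 3 lies within the scatter of both compound 1 and compound 2, so no compound stands apart. Compound 4 `CN1CCN(CCCCOc2c(O)cc3oc(-c4ccccc4)cc(=O)c3c2O)CC1` differs from compound 3 by hydrogen in place of methyl on an oxygen on an aromatic ring. Among the measured compounds shown here, no measured pair isolates this change. For the measured compounds named here, the only single-point step, a 1.2-fold lower number from compound 1 to compound 2 (0.06 log units; within the scatter), concerns a longer chain and bears only loosely here. Compound 2 and compound 3, which differ in two places at once, show values that are indistinguishable, which suggests that neither change moves the read-out much. Compound 4 is therefore expected to show no step beyond the scatter, a 1.1-fold lower number from compound 3 to compound 4 (0.03 log units; within the scatter). For compound 4 the estimate in this assay is 50000 nM, within 20000 nM to 130000 nM.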

Compound 4, half-maximal inhibitory concentration: 82900 nM
Beside the measured number, compound 4's estimate is 1.7-fold (0.22 log units) below it, and the stated range covers the measured number.
By their numbers in this assay, from the lowest: compounds 2, 3, 1 and 4 (each within the scatter of the next).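

Exchanging methoxy for hydroxy on this oxygen on an aromatic ring gives a 1.5-fold higher number from compound 3 to compound 4 (0.19 log units; within the scatter) in this assay and so shows that this single change does not move the read-out beyond the scatter. The two steps that change the chain end, a 1.6-fold higher number from compound 2 to compound 4 (0.20 log units; within the scatter) and a 1.4-fold higher number from compound 1 to compound 4 (0.13 log units; within the scatter), also stay within it. No measurement at hand accounts for these results.

As far as these compounds go, whether an ethoxy group on this oxygen would behave the same remains open. So does the effect of a carboxylic acid or a longer chain in place of the 4-methylpiperazin-1-yl end.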